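The source may hold more compounds than are shown below. What is called first, only, known or untested is meant among the compounds shown, and "the series" means these compounds.

Measured so far in an assay on HEK-293T cells for displacement of a labelled ligand from corticotropin-releasing factor receptor 1 (Homo sapiens), read by scintillation counting, with a stated time of 2 h; a lower number here means a stronger inhibitor, a higher number a weaker inhibitor:
compound 1 `CCCCN(CC)c1cc(C)nc2c1NC(=O)CN2c1ccc(C(C)(C)C)cc1Br`: 4.2 nM
compound 2 `CCCCN(CC)c1cc(C)nc2c1NC(=O)CN2c1ccc(OC)cc1C`: 4 nM
compound 3 `CCN(C)c1cc(C)nc2c1N(CCCCF)C(=O)CN2c1ccc(C(C)C)cc1Br`: 13.9 nM

Compound 2 holds the lowest of the three numbers in this assay; compound 1 sits within the scatter of it, and only compound 3 lies beyond the scatter, at the higher side. Compound 4 `CCCCN(CC)c1cc(C)nc2c1NC(=O)CN2c1ccc(C)cc1C` is not yet measured. Its difference from compound 2 is methyl in place of methoxy on an aromatic carbon. Among the measured compounds shown here, no measured pair isolates this swap. Compound 1 and compound 2 carry quite different groups on that aryl ring and still give numbers within the scatter of each other, which suggests the step from compound 2 to compound 4 is unlikely to move far beyond the scatter in either direction. Compound 4 is therefore expected to give about 6 nM, within 2 nM to 20 nM. The expected step is a 1.5-fold higher number from compound 2 to compound 4 (0.18 log units; within the scatter).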

Compound 4, inhibition constant: 3.9 nM
Estimate against measurement, compound 4: 1.5-fold (0.19 log units) above; the measured number falls inside the stated range.
By their numbers in this assay, from the lowest: compounds 4, 2 and 1 (each within the scatter of the next); then compound 3.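

In this assay, among the compounds shown here, the change from 4-methoxy-2-methylphenyl to 2,4-dimethylphenyl gives a 1.0-fold lower number from compound 2 to compound 4 (0.01 log units; within the scatter) and is the first matched pair. On this aromatic carbon, para to a large group, methoxy and its hydrogen-bond acceptor can therefore give way to methyl with no step beyond the scatter. No measured evidence accounts for this result.

Going by these compounds, it remains open how an amine, a carboxylic acid or a longer alkoxy chain would read in place of the methoxy. Whether the same swap stays within the scatter on a different amine side chain is also unresolved.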